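The source may hold more compounds than are shown below. What is called first, only, known or untested is meant among the compounds shown, and "the series" means these compounds.

Compound 2 `COc1ccc(-c2cc(C(=O)/C=C/c3cc(OC)c(OC)c(OC)c3)nc3cc(-c4ccccc4)nn23)cc1OC` is the reference point here. In a functional assay on DU-145 cells (Homo sapiens) for antiproliferative activity, read by MTT assay, with a stated time of 24 h (a lower number here means a stronger inhibitor, a higher number a weaker inhibitor), compound 2 gives 14700 nM. Two neighbours frame it. Compound 1 `COc1cc(/C=C/C(=O)c2cc(-c3cc(OC)c(OC)c(OC)c3)n3nc(-c4ccccc4)cc3n2)cc(OC)c1OC`, which carries one more methoxy group on an aromatic carbon, gives 17900 nM in this assay, and the step of a 1.2-fold lower number from compound 1 to compound 2 (0.09 log units; within the scatter) is too small to count as a real change. Compound 3 `COc1cc(-c2cc(/C=C/C(=O)c3ccccc3)nc3cc(-c4ccccc4)nn23)cc(OC)c1OC`, which carries the trimethoxyphenyl group on the other part of the shared core and a plain phenyl on the chain, gives 34300 nM in this assay, a number further from compound 2 than the scatter allows, so compound 2 has the lowest number of the three.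

Compound 4 `COc1ccc(-c2cc(C(=O)/C=C/c3ccc(C)cc3)nc3cc(-c4ccccc4)nn23)cc1OC` is not yet measured. It differs from compound 2 in one place: 4-methylphenyl in place of 3,4,5-trimethoxyphenyl on a double-bonded chain carbon bound to a double-bonded chain carbon. Among the compounds with values here, only the step from compound 1 to compound 2 bears on it, and that step, a 1.2-fold lower number from compound 1 to compound 2 (0.09 log units; within the scatter), was small; it involved a single methoxy group, whereas here three are exchanged for a methyl, so its guidance is limited. A moderate rise in the number, meaning weaker inhibition, is expected. For compound 4 the estimate in this assay is 25000 nM, within 10000 nM to 60000 nM, which is expected to be a step of a 1.7-fold higher number from compound 2 to compound 4 (0.23 log units; within the scatter).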

Compound 4, half-maximal inhibitory concentration: 19500 nM
Compound 4: the middle estimate sits 1.3-fold (0.11 log units) above what was measured; measured number inside the range.
By their numbers in this assay, from the lowest: compounds 2, 1, 4 and 3 (each within the scatter of the next, the first and the last beyond it).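

Putting 4-methylphenyl in place of 3,4,5-trimethoxyphenyl on the double-bonded chain carbon is the first change shown at this end of the chain, and in this assay the step is a 1.3-fold higher number from compound 2 to compound 4 (0.12 log units; within the scatter), too small to count as a real change. The three methoxy groups, and with them the group's 3 hydrogen-bond acceptors, can therefore be exchanged for a single methyl group with no reading beyond the scatter in this assay. No measurement at hand gives a reason for this result.

The compounds shown leave open whether the same holds for a different kind of group at this place, such as an amine or a carboxylic acid on the phenyl ring. Going by these compounds, it is also open whether a plain alkyl chain could stand in place of the ring altogether.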